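A few compounds are considered here, and "the series" means these few. Any claim that something is new, unique, unknown or untested is made for them only; others in the source may bear on it.

Compound 1 `COc1ccc(-c2cc(=O)c3c(OC)cc(OC)cc3n2S(=O)(=O)c2ccc(C=O)cc2)cc1` in a functional assay on SUP-B15 cells (Homo sapiens) for antiproliferative activity, with a stated time of 72 h (a lower number here means that less compound is needed, a higher number that more compound is needed for the effect), gives only a limit, > 34400 nM. Compound 2 `COc1ccc(-c2cc(=O)c3c(OC)cc(OC)cc3n2S(=O)(=O)c2cccc(Br)c2)cc1` likewise gives only a limit in this assay, > 58600 nM.

Compound 2 thus stands at a limit, not at a number. The step that the two limits leave unreadable from compound 1 to compound 2 cannot be read, since both ends sit at limits (the limit of > 34400 nM in this assay, at which 1 of the 2 values shown sits, (the limit of > 58600 nM in this assay, at which 1 of the 2 values shown sits)). Compound 3 `COc1ccc(-c2cc(=O)c3c(OC)cc(OC)cc3n2S(=O)(=O)c2ccc(OC)cc2)cc1` differs from compound 2 by 4-methoxyphenyl in place of 3-bromophenyl on a sulfonyl sulfur. Going by the values given here, no measured step bears on this change, so no direction can be derived from the data. Compound 3 is expected to remain at or near a limit in this assay, estimated at 50000 nM within 15000 nM to 150000 nM. The expected nominal step an at least 1.1-fold lower number from compound 2 to compound 3 (0.06 log units; that floor lies within the scatter) is therefore within scatter.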

Compound 3, half-maximal effective concentration: > 82700 nM
Compound 3: a limit, no number; the forecaster's own chance of this, stated with the estimate: 80%; at least 1.6-fold (0.21 log units) between middle value and limit.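

In this assay, going by these compounds alone, compound 3 gives > 82700 nM as a limit only, so with compound 1 and compound 2 also at limits, no step among the three can be read. The compounds shown leave open whether any group on the sulfonyl sulfur gives a measurable value in this assay at all.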